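The source may report more compounds than this note shows. Statements on the series, on what has been measured and on what is new or still open speak of the compounds shown alone.

Notes on the series. Compound 1 `CC(=O)N1CC2CC(C1)N2` gives 94% in an assay on SH-EP1 cells for agonist activity at Neuronal acetylcholine receptor; alpha4/beta2 (Homo sapiens), read by FLIPR and calcium flux (on this read-out lower numbers stand for smaller maximal responses and higher numbers for larger maximal responses), the higher of the two numbers in hand. Compound 2 `C[C@@H]1C[C@@H]1C(=O)N1CC2CC(C1)N2` gives 88% in this assay, and the step of a number 6 percentage points lower from compound 1 to compound 2 (within the scatter) lies within the scatter. Compound 3 `C[C@H]1C[C@@H]1C(=O)N1CC2CC(C1)N2` has not been measured. Its change from compound 1 is 2-methylcyclopropyl in place of methyl on a carbonyl carbon, so compound 3 carries the same 2-methylcyclopropyl as compound 2, differing only in the arrangement of its two defined stereocentres. Among the measured compounds shown here, the one step that bears on this is a number 6 percentage points lower from compound 1 to compound 2 (within the scatter), a change within the scatter for a group of the same make-up. Nothing in hand separates the two forms of the group, so no step beyond the scatter is expected in this assay. The estimated step of a number 6 percentage points lower from compound 1 to compound 3 (within the scatter) is accordingly small. Compound 3 is expected to give 88%, with a range of 75% to 100%.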

Compound 3, largest response reached (Emax), in percent of the reference or control that the assay uses: 67%
Compound 3: the middle estimate sits 21 percentage points above what was measured; the whole stated range lies above it.
By their numbers in this assay, from the lowest: compound 3; then compounds 2 and 1 (each within the scatter of the next).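

In this assay, replacing methyl with 2-methylcyclopropyl on the carbonyl carbon is not tolerated equally by every form of the group: the step is a number 27 percentage points lower from compound 1 to compound 3 (beyond the scatter), whereas compound 2 stays within the scatter of compound 1. With the same atoms and bonds in both compounds, a number 21 percentage points lower from compound 2 to compound 3 (beyond the scatter) shows that the maximal response at this position depends on the stereo arrangement of the group and not on its make-up alone. The structural record for this pair carries one qualification: the fact that one of compounds 2 and 3 is drawn with a defined configuration and the other without, at the place where they differ

The compounds shown leave open how the remaining stereo forms of 2-methylcyclopropyl behave. They also leave open whether an unsubstituted cyclopropyl, an ethyl or a longer chain on the carbonyl carbon would keep the response of compound 1.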